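The source may hold more compounds than are shown below. What is called first, only, known or untested is meant among the compounds shown, and "the series" means these compounds.

Three compounds built on one shared core were tested in a functional assay on DU-145 cells (Homo sapiens) for cytotoxicity, read by MTT assay, with a stated time of 48 h; a lower number here means a stronger inhibitor, a higher number a weaker inhibitor. Compound 1 `O=C(Nc1nc2ccc(Cl)cc2s1)c1cc(-c2ccc(F)cc2)n2nc(-c3ccccc3)cc2n1` gives 17600 nM. Compound 2 `O=C(Nc1nc2ccc(F)cc2s1)c1cc(-c2ccc(F)cc2)n2nc(-c3ccccc3)cc2n1` gives 22900 nM in this assay. Compound 3 `COc1cc(-c2cc(C(=O)Nc3nc4ccc(F)cc4s3)nc3cc(-c4ccccc4)nn23)cc(OC)c1OC` gives 25700 nM. The step of a 1.3-fold higher number from compound 1 to compound 2 (0.11 log units; within the scatter) and the step of a 1.1-fold higher number from compound 2 to compound 3 (0.05 log units; within the scatter) both lie within the scatter, so the three numbers cannot be ranked; compound 2 stands second highest of the three only on paper, with compound 3 nearest and compound 1 furthest, both within the scatter.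

Compound 4 `COc1ccc2nc(NC(=O)c3cc(-c4ccc(F)cc4)n4nc(-c5ccccc5)cc4n3)sc2c1` has not yet been measured. It differs from compound 2 by methoxy in place of fluoro on an aromatic carbon. For the measured compounds named here, the one measured step at that same ring, a 1.3-fold higher number from compound 1 to compound 2 (0.11 log units; within the scatter), stayed within the scatter, and the other, a 1.1-fold higher number from compound 2 to compound 3 (0.05 log units; within the scatter), which touched a different part of the molecule, did likewise. No shift beyond the scatter is therefore expected in this assay. Compound 4 is expected to give about 22000 nM, within a range from 10000 nM to 48000 nM. That estimate means the step of a 1.0-fold lower number from compound 2 to compound 4 (0.02 log units; within the scatter) is expected to remain within the scatter.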

Compound 4, half-maximal inhibitory concentration: 15400 nM
The estimate for compound 4 lay 1.4-fold (0.15 log units) above the measured number; the range from low to high includes it.
By their numbers in this assay, from the lowest: compounds 4, 1, 2 and 3 (each within the scatter of the next).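

In this assay, the change from fluoro to methoxy on this carbon stays within the scatter (a 1.5-fold lower number from compound 2 to compound 4 (0.17 log units; within the scatter)), and so does the change from chloro to methoxy (a 1.1-fold lower number from compound 1 to compound 4 (0.06 log units; within the scatter)). The earlier compounds shown here compared only two halogens here, whereas methoxy is a group of a different kind, with two heavy atoms in place of one and a hydrogen-bond acceptor where fluoro has none. Across compounds 1, 2 and 4, this position has therefore taken all three groups without a change that can be read in this assay, and nothing available bears on why these groups read alike. The compounds shown leave open whether an amine or a carboxylic acid on the same carbon would also stay within the scatter. They also leave open whether methoxy here would read the same with 3,4,5-trimethoxyphenyl in place of 4-fluorophenyl.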